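Triazole substituent swap in the shared core series

A few compounds are considered here, and "the series" means these few. Any claim that something is new, unique, unknown or untested is made for them only; others in the source may bear on it.

Measured compounds:
Compound 1, `COc1ccc(-c2cn(C/C=C3\OC(=O)C(OCc4ccccc4)=C3OCc3ccccc3)nn2)cc1`, > 100000 nM (a limit)
Compound 2, `C[Si](C)(C)c1cn(C[C@H](O)[C@H]2OC(=O)C(OCc3ccccc3)=C2OCc2ccccc2)nn1`, 19200 nM
Compound 3, `O=C1O[C@H]([C@@H](O)Cn2cc(-c3cc(C(F)(F)F)cc(C(F)(F)F)c3)nn2)C(OCc2ccccc2)=C1OCc1ccccc1`, 28900 nM

In a functional assay on A549 cells (Homo sapiens) for antiproliferative activity, read by MTT assay, with a stated time of 72 h (a lower number here means a stronger inhibitor, a higher number a weaker inhibitor), compound 1 gives > 100000 nM, which is a limit of the assay and not a number, so it is set aside for comparison; this is noted in the limit of > 100000 nM in this assay, at which 1 of the 3 values shown sits. Compound 2 gives the lowest of the two numbers in this assay, with compound 3 as its nearest neighbour, and the gap between the two lies within the scatter, so no order between them is claimed.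

Compound 4, `O=C1O[C@H]([C@@H](O)Cn2cc(C3CC3)nn2)C(OCc2ccccc2)=C1OCc1ccccc1`, is not yet measured. It differs from compound 2 at one place: a group of 3 heavy atoms (3 carbon; one three-membered non-aromatic ring of carbon only) in place of a group of 4 heavy atoms (3 carbon, 1 silicon; no ring), on an aromatic carbon. The change sits on an aromatic carbon of a five-membered aromatic ring with 3 nitrogen, on the shared core of compound 2.

Among the measured compounds shown here, no step between two measured compounds separates one group at that position from another, so the size of this step cannot be read from the series itself. Both numbered values sit in a similar weak region, which suggests the group at that position matters little. Compound 4 is expected to land near compound 2, with the step of a 1.6-fold higher number from compound 2 to compound 4 (0.19 log units; within the scatter) estimated as no larger than the scatter or a modest move toward a higher number. The estimate for compound 4 is 30000 nM, between 10000 nM and 100000 nM.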

Compound 4, half-maximal inhibitory concentration: 43900 nM
For compound 4 the middle estimate is 1.5-fold (0.17 log units) below the measured one, and the stated range covers the measured number.
By their numbers in this assay, from the lowest: compounds 2, 3 and 4 (each within the scatter of the next, the first and the last beyond it). At a limit, above all of these: compound 1.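

In this assay, among the compounds shown here, the change from the silicon-bearing group to cyclopropyl, on an aromatic carbon of a five-membered aromatic ring with 3 nitrogen, gives a 2.3-fold higher number from compound 2 to compound 4 (0.36 log units; beyond the scatter) as the first step that can be read at this position. The earlier values could only suggest that the group here matters little; this step shows that the position does respond to a swap, though modestly, and compound 4 gives 43900 nM with no silicon in the group, so silicon is not needed for a measurable number in this weak region. The data shown offer nothing that explains the size or direction of this step.

Open, going by these compounds, is whether an amine, a carboxylic acid or a longer chain on that same aromatic carbon would produce a larger step or lift the series out of this weak region. Also open, on these data alone, is what the chain carrying the hydroxyl contributes, since compound 1 departs from the others at that chain as well as at the ring substituent, and its > 100000 nM is a limit of the assay and not a number, which cannot be assigned to either change.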